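Methoxycarbonyl for chloro on the benzyl group

The compounds below may be only part of what the source reports. "The series", "measured", "known", "first", "only" and "open" are said of these compounds alone.

Compound 1 `O=c1c2cnn(-c3ccc(F)cc3)c2ncn1CC1(O)CCN(Cc2cccnc2)CC1`: "not determined" (no result reported)
Compound 2 `O=c1c2cnn(-c3ccc(F)cc3)c2ncn1CC1(O)CCN(Cc2ccccc2F)CC1`: 9800 nM
Compound 3 `O=c1c2cnn(-c3ccc(F)cc3)c2ncn1CC1(O)CCN(Cc2ccc(Cl)cc2Cl)CC1`: 3300 nM

Three compounds share one core and differ only in the group carried on the saturated chain carbon bound to the amine nitrogen in the ring. In an assay on Sf21 cells for inhibition of ubiquitin carboxyl-terminal hydrolase 7 (Homo sapiens), read by spectrophotometry, with stated times of 30 min and 2 h (on this read-out higher numbers stand for weaker inhibition and lower numbers for stronger inhibition), compound 2 gives 9800 nM, while compound 3 gives 3300 nM; for compound 1 the outcome is "not determined" (no result reported). Going by the values given here, the single measured step runs a 3.0-fold lower number from compound 2 to compound 3 (0.47 log units; beyond the scatter). Compound 3 thus holds the lowest of the two numbers, with compound 2 its nearest neighbour beyond the scatter.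

Compound 4 `COC(=O)c1ccc(CN2CCC(O)(Cn3cnc4c(cnn4-c4ccc(F)cc4)c3=O)CC2)c(Cl)c1` follows from compound 3 by methoxycarbonyl in place of chloro on an aromatic carbon. Among the compounds with values here, no measured step bears directly on this exchange: the step from compound 2 to compound 3 altered both the number and the kind of halogen on the ring, whereas compound 4 keeps the chloro group that sits meta to the new substituent and only replaces the other chloro. With a single modest step as the whole reference, and none touching a methoxycarbonyl group, there is no ground to expect a change beyond the scatter in either direction. Compound 4 is therefore expected to give 3500 nM in this assay, within 900 nM to 14000 nM. The expected step from compound 3 is a 1.1-fold higher number from compound 3 to compound 4 (0.03 log units; within the scatter).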

Compound 4, half-maximal inhibitory concentration: 800 nM
The estimate for compound 4 lay 4.4-fold (0.64 log units) above the measured number; the measured number lies below the stated range.
By their numbers in this assay, from the lowest: compound 4; then compound 3; then compound 2.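

In this assay methoxycarbonyl in place of chloro gives a 4.1-fold lower number from compound 3 to compound 4 (0.62 log units; beyond the scatter) and so shows that this aromatic carbon, meta to a chloro group and para to a large group, accepts a group of four heavy atoms with two hydrogen-bond acceptors where a single chlorine stood, and that inhibition grows stronger beyond the scatter. Going by these compounds alone, the earlier compounds varied only halogens on the benzyl ring, whereas the exchange of 2-fluorophenyl for 2-chloro-4-(methoxycarbonyl)phenyl gives a 12-fold lower number from compound 2 to compound 4 (1.09 log units; beyond the scatter) and is the first large step, so a non-halogen group at this place moves the number further than the halogen change alone did. No measurement at hand accounts for the lower number of compound 4.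

The compounds shown leave open whether a carboxylic acid, a primary amide or a nitrile at the same aromatic carbon would give a number like that of compound 4, or whether the ester itself is required. They also leave open whether the remaining chloro group contributes, since every benzyl ring with a measured value here carries a halogen on that carbon, and a plain hydrogen there would settle it.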